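This account rests on a few compounds, and the source may have more. Where it says the series, first, only, none or still open, it means among the compounds named here.

Compound 3 (`FC(F)(F)c1ccc(CNc2nc(-c3ccccc3C(F)(F)F)nc3ccccc23)cc1`) is one of three close relatives that share a core and differ only in the group carried on the outer aromatic ring. In an assay on a protein complex for inhibition of ubiquitin carboxyl-terminal hydrolase 1/WD repeat-containing protein 48 (Homo sapiens), read by fluorescence (a higher number here means a weaker inhibitor, a lower number a stronger inhibitor), compound 1 (`FC(F)(F)c1ccccc1-c1nc(NCc2ccccc2)c2ccccc2n1`) gives 3100 nM, compound 2 (`COc1ccc(CNc2nc(-c3ccccc3C(F)(F)F)nc3ccccc23)cc1`) gives 6200 nM and compound 3 gives 8900 nM. Compound 3 therefore carries the highest number of the three: the step of a 2.9-fold higher number from compound 1 to compound 3 (0.46 log units; beyond the scatter), a trifluoromethyl in place of a hydrogen on an aromatic carbon, lies beyond the scatter, whereas the step of a 1.4-fold higher number from compound 2 to compound 3 (0.16 log units; within the scatter), a trifluoromethyl in place of a methoxy, stays within it, so compound 2 and compound 3 cannot be separated in this assay.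

Compound 4 (`N#Cc1ccc(CNc2nc(-c3ccccc3C(F)(F)F)nc3ccccc23)cc1`) is reached from compound 3 by cyano in place of trifluoromethyl on an aromatic carbon. For the measured compounds named here, no measured step involves a cyano group. The nearest guides are a 2.0-fold higher number from compound 1 to compound 2 (0.30 log units; within the scatter) and a 2.9-fold higher number from compound 1 to compound 3 (0.46 log units; beyond the scatter), which show that adding a group at this place raised the number modestly at most, and a 1.4-fold higher number from compound 2 to compound 3 (0.16 log units; within the scatter), which shows that exchanging one such group for another changed little. The step to compound 4 is expected to be small, a 1.5-fold lower number from compound 3 to compound 4 (0.17 log units; within the scatter), not beyond the scatter. Compound 4 is estimated at 6000 nM, between 2500 nM and 15000 nM.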

Compound 4, half-maximal inhibitory concentration: 5700 nM
Compound 4: middle estimate off by 1.1-fold (0.02 log units), on the high side; low and high end bracket the measured number.
By their numbers in this assay, from the lowest: compounds 1, 4, 2 and 3 (each within the scatter of the next, the first and the last beyond it).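

The 4-cyanophenyl group brings a new kind of substituent to this position, since cyano carries a hydrogen-bond acceptor and trifluoromethyl carries none, yet in this assay the exchange gives only a 1.6-fold lower number from compound 3 to compound 4 (0.19 log units; within the scatter), and replacing methoxy with cyano gives a 1.1-fold lower number from compound 2 to compound 4 (0.04 log units; within the scatter), so compound 2, compound 3 and compound 4 cannot be told apart. Set against hydrogen, cyano gives a 1.8-fold higher number from compound 1 to compound 4 (0.26 log units; within the scatter), which stays inside the scatter, while trifluoromethyl gives a 2.9-fold higher number from compound 1 to compound 3 (0.46 log units; beyond the scatter), so the only clear separation among these substituents and hydrogen rests on that single modest step. Nothing shown here explains these numbers.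

Still open, from the compounds shown here alone, is how this position responds to groups of a different kind, such as an amine, a carboxylic acid or a longer carbon chain. The compounds shown also leave unsettled whether any group at this place can give a number clearly lower than that of compound 1, at 3100 nM.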